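A Methyl on the Sulfonamide Nitrogen of Compound 1

The compounds below may be only part of what the source reports. "The series", "measured", "known", "first", "only" and "open" are said of these compounds alone.

For the measured compounds named here, compound 1 `CC[C@@H]1C(=O)N(C)c2cnc(Nc3ccc(S(N)(=O)=O)cc3)nc2N1C1CCCC1` is one of three compounds measured in a functional assay on Huh-7 cells (Homo sapiens) for antiproliferative activity, read by CCK-8 assay, with a stated time of 72 h; on this read-out higher numbers stand for weaker inhibition of growth and lower numbers for stronger inhibition of growth. In that assay compound 1 gives 1300 nM. Compound 3 `CCCNC(=O)c1ccc2c(ccn2-c2ncc3c(n2)N(C2CCCC2)[C@H](CC)C(=O)N3C)c1` gives 689 nM; the gap between compound 1 and compound 3 lies within the scatter, so no order can be read from it. Compound 2 `CCCCNS(=O)(=O)c1ccc(Nc2ncc3c(n2)N(c2ccn(C)n2)C(CC)C(=O)N3C)cc1` gives 3750 nM, and its gap from compound 1 lies beyond the scatter, with compound 2 the higher number. Compound 1 therefore stands second highest of the three numbers.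

Compound 4 `CC[C@@H]1C(=O)N(C)c2cnc(Nc3ccc(S(=O)(=O)NC)cc3)nc2N1C1CCCC1` has not yet been measured. It differs from compound 1 in one place: methyl in place of hydrogen on a sulfonamide nitrogen. Cut one bond further out, the same change reads amino to methylamino, sulfamoyl to methylsulfamoyl.

Going by the values given here, no pair of measured compounds differs in this one place alone, so no measured step shows what this change does here. Compound 2 differs from compound 1 in more than one place, so only its two values can be set side by side, not the change itself. The expectation is modest: a 1.2-fold higher number from compound 1 to compound 4 (0.06 log units; within the scatter) is the estimated step, with no direction beyond the scatter. Compound 4 is estimated at 1500 nM in this assay, within a range from 600 nM to 4000 nM.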

Compound 4, concentration for 50% growth inhibition: 99 nM
Compound 4: the middle estimate sits 15-fold (1.18 log units) above what was measured; measured number below the stated range.
By their numbers in this assay, from the lowest: compound 4; then compounds 3 and 1 (each within the scatter of the next); then compound 2.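

In this assay, the sulfonamide nitrogen of compound 1 proves to be a place where a very small change counts: the step is a 13-fold lower number from compound 1 to compound 4 (1.12 log units; beyond the scatter), large and well beyond the scatter. The earlier compounds shown here could not show this, since no measured pair differed at this nitrogen alone, and compound 2 differs from compound 1 in more than one place. The step now shows that the free sulfonamide hydrogen is not needed for growth inhibition in these cells, and that methyl in its place, a single carbon with no ring and no net charge, gives stronger inhibition of growth, though nothing shown here accounts for a step of this size.

The compounds shown leave open whether the effect is particular to methyl or persists with ethyl, a longer propyl chain or a cyclopropyl ring on the same nitrogen, and whether a second methyl on that nitrogen, giving a dimethylsulfamoyl group, would keep it. They also leave open whether methyl on this nitrogen would give a similar step on a core carrying a different group in place of the cyclopentyl ring.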